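The compounds below may be only part of what the source reports. "The series", "measured", "known", "first", "only" and "open" are said of these compounds alone.

In a functional assay on LOX IMVI cells (Homo sapiens) for cytotoxicity, read by MTT assay, with a stated time of 24 h (on this read-out higher numbers stand for weaker inhibition and lower numbers for stronger inhibition), compound 1 `COc1cc(-c2nc(-c3ccccc3)[nH]c2-c2ccnc(NCCCNS(=O)(=O)c3ccc(Cl)cc3)n2)ccc1F` gives 83100 nM, compound 2 `O=S(=O)(NCCCNc1nccc(-c2[nH]c(-c3ccccc3)nc2-c2ccc(F)c(O)c2)n1)c1ccc(Cl)cc1` gives 14200 nM and compound 3 `O=S(=O)(NCCCNc1nccc(-c2[nH]c(-c3ccccc3)nc2-c2ccc(Cl)c(O)c2)n1)c1ccc(Cl)cc1` gives 61300 nM. The shifts so far are a 5.9-fold lower number from compound 1 to compound 2 (0.77 log units; beyond the scatter), a 4.3-fold higher number from compound 2 to compound 3 (0.64 log units; beyond the scatter) and a 1.4-fold lower number from compound 1 to compound 3 (0.13 log units; within the scatter). Compound 3 therefore stands in the upper part of this small range, level with compound 1. Compound 4 `O=S(=O)(NCCCNc1nccc(-c2[nH]c(-c3ccccc3)nc2-c2ccc(Cl)c(O)c2)n1)c1cccc2ccccc12` carries naphthalen-1-yl in place of 4-chlorophenyl on a sulfonyl sulfur. Within the data shown here, no measured step changes that group, so these steps offer only a modest size and no direction for this assay. The expectation is therefore no shift beyond the scatter, and the expected step is a 1.5-fold lower number from compound 3 to compound 4 (0.19 log units; within the scatter). The estimated value for compound 4 is 40000 nM, with an expected range of 12000 nM to 100000 nM.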

Compound 4, half-maximal inhibitory concentration: 7720 nM
The estimate for compound 4 lay 5.2-fold (0.71 log units) above the measured number, and the stated range ends above it.
By their numbers in this assay, from the lowest: compounds 4 and 2 (each within the scatter of the next); then compounds 3 and 1 (each within the scatter of the next).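

Working from this assay, the sulfonyl sulfur is a position that responds to its aryl group: naphthalen-1-yl in place of 4-chlorophenyl gives a 7.9-fold lower number from compound 3 to compound 4 (0.90 log units; beyond the scatter), a step beyond the scatter. Among these compounds, the earlier steps touched only the substituents on the other aromatic ring, so this is the first sign that the sulfonamide aryl group also moves the number. Nothing available explains this step.

Open, going by these compounds, is whether the step follows the added ring or the lost chlorine, which plain phenyl or naphthalen-2-yl on the sulfonyl sulfur would separate. Also open, on these data alone, is whether naphthalen-1-yl gives a similar step on the fluoro compound 2.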